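Bromine Added to a Weak Compound: Expecting a Modest Gain

The compounds below may be only part of what the source reports. "The series", "measured", "known", "first", "only" and "open" are said of these compounds alone.

Compounds measured so far:
Compound 1 `COc1ccccc1Oc1c(N)nc(-c2ccc(F)cc2)nc1Cl` gives 28200 nM in a functional assay on A-375 cells (Homo sapiens) for cytotoxicity, read by CCK-8 assay, with a stated time of 24 h; a lower number here means a stronger inhibitor, a higher number a weaker inhibitor.
Compound 2 `COc1ccccc1Oc1c(N)nc(-c2ccc(Br)cc2)nc1Cl` gives 63 nM in this assay.
Compound 3 `COc1ccccc1Oc1c(N)nc(-c2ccccc2)nc1OCCO` gives > 80000 nM in this assay, which is a limit of the assay and not a number.

Compound 3 therefore stands at the edge of what this assay can report, sitting at the limit of > 80000 nM in this assay, at which 1 of the 3 values shown sits; no true number is known for it. Compound 4 `COc1ccccc1Oc1c(N)nc(-c2cccc(Br)c2)nc1OCCO` differs from compound 3 only in one place: bromo in place of hydrogen on an aromatic carbon, on an aromatic carbon of a six-membered aromatic ring of carbon only, meta to a large group.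

For the measured compounds named here, only one measured step speaks to bromine on this ring. The change a 450-fold lower number from compound 1 to compound 2 (2.65 log units; beyond the scatter) shows that a bromine in place of a fluorine gave a very large gain, though at a different place on the ring and with a different group on the core. Bromine in place of hydrogen is a related but not identical change, so a smaller gain in this assay is expected, and the starting point is a limit rather than a number.

Compound 4 is therefore expected to give about 25000 nM, with a likely range from 5000 nM to 80000 nM, meaning an estimated step of an at least 3.2-fold lower number from compound 3 to compound 4 (0.50 log units; beyond the scatter).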

Compound 4, half-maximal inhibitory concentration: 650 nM
Beside the measured number, compound 4's estimate is 38-fold (1.59 log units) above it, outside the stated range (below it).
By their numbers in this assay, from the lowest: compound 2; then compound 4; then compound 1. At a limit, above all of these: compound 3.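

In this assay, one bromine in place of one hydrogen on the phenyl ring gives an at least 120-fold lower number from compound 3 to compound 4 (2.09 log units; beyond the scatter). For the compounds shown here, the earlier step showed only bromo replacing fluoro, at a different place on the ring and with a different group on the core, so this is the first sign that adding bromine to an unsubstituted phenyl can by itself give a large gain, here on an aromatic carbon meta to a large group. Compound 3 gives > 80000 nM, which is a limit of the assay and not a number, so the step has a firm lower bound but no known true size: the limit of > 80000 nM in this assay, at which 1 of the 4 values shown sits.

The compounds shown leave open whether bromine is needed here or whether another group in the same place, such as chloro, methyl, trifluoromethyl or an amine, would give a similar change. No pair shown sets a bromine in this place against a bromine elsewhere on the same ring with everything else unchanged, so how much the place itself matters also remains unknown.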